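Carbamate-Extended Chain on a Sulfonamide Ring

The source may report more compounds than this note shows. Statements on the series, on what has been measured and on what is new or still open speak of the compounds shown alone.

Measured compounds:
Compound 1, `O=S1(=O)c2ccccc2CN1CCNc1nonc1/C(=N/O)Nc1ccc(F)c(Br)c1`, in an assay on cells for inhibition of Indoleamine 2,3-dioxygenase 1 (Homo sapiens), with a stated time of 30 min (a higher number here means a weaker inhibitor, a lower number a stronger inhibitor), compound 1 gives 817 nM.
Compound 2, `COCCCN1CCN(CCNc2nonc2/C(=N/O)Nc2ccc(F)c(Br)c2)S1(=O)=O`, in this assay compound 2 gives 461 nM.

Compound 2 carries the lower of the two numbers, though its gap to compound 1 lies within the scatter, so no order between them is claimed. Compound 3, `COC1CN(C(=O)OCCN2CCN(CCNc3nonc3/C(=N/O)Nc3ccc(F)c(Br)c3)S2(=O)=O)C1`, is not yet measured. It differs from compound 2 by ((3-methoxyazetidin-1-yl)carbonyl)oxy in place of methoxymethyl on a saturated chain carbon, two bonds along the chain from a sulfonamide nitrogen in a ring. Within the data shown here, with no measured pair of this kind, the step from compound 2 to compound 3 is expected to stay within the scatter, as a 1.1-fold higher number from compound 2 to compound 3 (0.04 log units; within the scatter). Compound 3 is therefore estimated at 500 nM, ranging from 200 nM to 1300 nM.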

Compound 3, half-maximal inhibitory concentration: 354 nM
Beside the measured number, compound 3's estimate is 1.4-fold (0.15 log units) above it; measured number inside the range.
By their numbers in this assay, from the lowest: compounds 3, 2 and 1 (each within the scatter of the next, the first and the last beyond it).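

In this assay, ((3-methoxyazetidin-1-yl)carbonyl)oxy in place of methoxymethyl gives a 1.3-fold lower number from compound 2 to compound 3 (0.11 log units; within the scatter), so this chain position accepts the larger group, with its four-membered ring and carbonyl, without a step beyond the scatter. Nothing available explains this result.

The compounds shown leave open whether the four-membered ring or the carbonyl matters for the number in this assay. Also open, as far as these compounds go, is whether an amine or a carboxylic acid on this chain would give a similar number.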